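Replacing a Branched Alkyl with an Aminoethyl Group

A few compounds are considered here, and "the series" means these few. Any claim that something is new, unique, unknown or untested is made for them only; others in the source may bear on it.

Three compounds share one core and differ only in the amine attached to it:

Compound 1, `CCC(C)C(N)c1cc(C(F)(F)F)ccc1N1CCN(C(=O)CCc2ccc(Cl)cc2Cl)CC1`, gives 160 nM in an assay on HEK293 cells for displacement of a labelled ligand from Melanocortin receptor 4 (Homo sapiens); on this read-out lower numbers stand for stronger inhibition and higher numbers for weaker inhibition.
Compound 2, `CCN[C@H](c1cc(C(F)(F)F)ccc1N1CCN(C(=O)CCc2ccc(Cl)cc2Cl)CC1)C(C)CC`, gives 92 nM in this assay.
Compound 3, `CCC(C)CN[C@H](c1cc(C(F)(F)F)ccc1N1CCN(C(=O)CCc2ccc(Cl)cc2Cl)CC1)C(C)CC`, gives 2800 nM in this assay.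

Compound 3 stands highest of the three, well beyond the scatter: an 18-fold higher number from compound 1 to compound 3 (1.24 log units; beyond the scatter) and a 30-fold higher number from compound 2 to compound 3 (1.48 log units; beyond the scatter). Compound 4, `CCC(C)[C@H](NC[C@H](C)N)c1cc(C(F)(F)F)ccc1N1CCN(C(=O)CCc2ccc(Cl)cc2Cl)CC1`, is not yet measured. It differs from compound 3 in one place: 1-aminoethyl in place of sec-butyl on a saturated chain carbon bound to an amine nitrogen. For the measured compounds named here, the step that bears most directly on this is the one from compound 2 to compound 3, which shows the cost of putting a sec-butyl where a methyl had been on that chain carbon. Compound 4 takes that sec-butyl away again and puts a shorter group there. The step between compound 1 and compound 2, a 1.7-fold lower number from compound 1 to compound 2 (0.24 log units; within the scatter), lies within the scatter, so a small group on the amine nitrogen has so far been tolerated. Given a 30-fold higher number from compound 2 to compound 3 (1.48 log units; beyond the scatter), and given that the incoming group is nearer in size to the ethyl of compound 2, a large drop is expected: a 14-fold lower number from compound 3 to compound 4 (1.15 log units; beyond the scatter). Compound 4 is therefore estimated at 200 nM, with a range from 50 nM to 800 nM.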

Compound 4, inhibition constant: 89 nM
Beside the measured number, compound 4's estimate is 2.2-fold (0.35 log units) above it, within the range that was stated.
By their numbers in this assay, from the lowest: compounds 4, 2 and 1 (each within the scatter of the next); then compound 3.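

In this assay, a chain longer than the ethyl of compound 2 is not costly in itself: with 1-aminoethyl on the saturated chain carbon bound to the amine nitrogen, the loss seen with sec-butyl is gone (a 31-fold lower number from compound 3 to compound 4 (1.50 log units; beyond the scatter)). The result also stays level with the two simpler amines (a 1.0-fold lower number from compound 2 to compound 4 (0.01 log units; within the scatter); a 1.8-fold lower number from compound 1 to compound 4 (0.25 log units; within the scatter)), and both steps lie within the usual scatter. This position can therefore carry a branched group, and the weak binding of compound 3 goes with sec-butyl in particular rather than with any group larger than methyl; no measurement here accounts for the difference between these two groups.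

The compounds shown do not separate the effect of the amine from that of the shorter chain, and a plain ethyl on that chain carbon, with the same carbons as 1-aminoethyl but no nitrogen, would address this. Also open, from the compounds shown here alone, are how a carboxylic acid or a longer chain ending in an amine would read there, and what the opposite configuration at the new stereocentre would give.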